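This account rests on a few compounds, and the source may have more. Where it says the series, first, only, none or still open, it means among the compounds named here.

Compound 1 (`COc1cc(OC)c(C(=O)/C=C/c2ccccc2OC)c(OC)c1`) gives 13000 nM in a functional assay on MDA-MB-231 cells (Homo sapiens) for cytotoxicity, with a stated time of 48 h; on this read-out higher numbers stand for weaker inhibition and lower numbers for stronger inhibition
Compound 2 (`COc1cccc(/C=C/C(=O)c2c(OC)cc(OC)cc2OC)c1`) gives 8700 nM in this assay
Compound 3 (`COc1cc(O)c(C(=O)/C=C/c2ccccc2OC)c(OC)c1`) gives > 20000 nM in this assay, a limit and not a number

For the measured compounds named here, compound 2 cannot be told apart from the only other true number, as the comparison shows a 1.5-fold lower number from compound 1 to compound 2 (0.17 log units; within the scatter). Compound 4 (`COc1cc(OC)c(C(=O)/C=C/c2ccc(F)cc2)c(OC)c1`) has yet to be measured. Its difference from compound 2 is 4-fluorophenyl in place of 3-methoxyphenyl on a double-bonded chain carbon bound to a double-bonded chain carbon, which amounts to 4-fluorophenyl in place of 3-methoxyphenyl on a double-bonded chain carbon bound to a double-bonded chain carbon.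

Two measured steps are available. The more relevant one changes the same place, with 3-methoxyphenyl in place of 2-methoxyphenyl, and it gave a 1.5-fold lower number from compound 1 to compound 2 (0.17 log units; within the scatter). The other is a different change, hydrogen in place of methyl on an oxygen on an aromatic ring, and it gave an at least 1.5-fold higher number from compound 1 to compound 3 (0.18 log units; that floor lies within the scatter), so it bears only weakly on this question. Going by the values given here, no measured compound carries 4-fluorophenyl, which leaves the forecast loose. Among the compounds with values here, the one swap at this place stayed inside the scatter, so no shift beyond the scatter is expected in this assay, and the expected step is a 1.0-fold higher number from compound 2 to compound 4 (0.01 log units; within the scatter). For compound 4 the estimated value is 9000 nM, with an expected range from 3500 nM to 20000 nM.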

Compound 4, half-maximal inhibitory concentration: 10700 nM
Compound 4: middle estimate off by 1.2-fold (0.08 log units), on the low side; measured number inside the range.
By their numbers in this assay, from the lowest: compounds 2, 4 and 1 (each within the scatter of the next). At a limit, above all of these: compound 3.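

The earlier compounds had shown this place, on a double-bonded chain carbon bound to a double-bonded chain carbon, only with one methoxyphenyl group swapped for another, whereas compound 4 carries no methoxy group there, and in this assay the swap to 4-fluorophenyl gives a 1.2-fold higher number from compound 2 to compound 4 (0.09 log units; within the scatter). Set against the 2-methoxyphenyl group, the same swap gives a 1.2-fold lower number from compound 1 to compound 4 (0.08 log units; within the scatter). The three groups therefore cannot be told apart in these compounds, even though 4-fluorophenyl has 0 hydrogen-bond acceptors where 3-methoxyphenyl has 1, so at this place a swap that removes the oxygen and brings in fluorine still leaves the number within the scatter.

Going by these compounds, compound 3 remains a limit of the assay and not a number, which leaves the effect of its change without a size: the limit of > 20000 nM in this assay, at which 1 of the 4 values shown sits. Whether an amine or a carboxylic acid at this place would take the number beyond the scatter stays open, as every group seen there so far is a substituted phenyl without either.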